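Three Measured Analogues and One Expected Value

The compounds below may be only part of what the source reports. "The series", "measured", "known", "first", "only" and "open" are said of these compounds alone.

Three compounds of a shared core have been measured in a functional assay on HeLa cells (Homo sapiens) for antiproliferative activity, with a stated time of 24 h; on this read-out lower numbers stand for stronger inhibition and higher numbers for weaker inhibition:

Compound 1 `NC(=O)c1c(NC(=O)c2ccccc2Cl)sc2c1CCN(Cc1c(Cl)cccc1Cl)C2` gives 28800 nM.
Compound 2 `NC(=O)c1c(NC(=O)c2ccccc2Cl)sc2c1CCN(C(=S)Nc1cccc3ccccc13)C2` gives 30800 nM.
Compound 3 `NC(=O)c1c(NC(=O)c2ccccc2Cl)sc2c1CCN(C(=O)Nc1ccccc1Cl)C2` gives 45400 nM.

Compound 3 stands with the highest of the three numbers, but neither neighbour is separated from it beyond the scatter: compound 2 and compound 1 sit close by, and all three values lie within the usual spread of repeated measurements. Among the measured compounds shown here, the one single-place step among them, a 1.6-fold higher number from compound 1 to compound 3 (0.20 log units; within the scatter), is itself within the scatter. Compound 2 differs from compound 3 in more than one place, so its value can only be read as a second number near that of compound 3.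

Compound 4 `NC(=O)c1c(NC(=O)c2ccccc2Cl)sc2c1CCN(C(=S)Nc1ccccc1Br)C2` is not yet measured. It differs from compound 3 by a group of 10 heavy atoms (7 carbon, 1 nitrogen, 1 sulfur, 1 bromine; one six-membered aromatic ring of carbon only) in place of a group of 10 heavy atoms (7 carbon, 1 nitrogen, 1 oxygen, 1 chlorine; one six-membered aromatic ring of carbon only), on an amine nitrogen in a ring. The measured step from compound 1 to compound 3 exchanged the same position and moved the number only within the scatter; compound 2, with another group on that nitrogen, also sits in the same narrow band. The step of a 1.3-fold lower number from compound 3 to compound 4 (0.10 log units; within the scatter) is therefore expected to be none beyond the scatter, in either direction. Compound 4 is estimated at 36000 nM, with a range from 15000 nM to 85000 nM.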

Compound 4, half-maximal inhibitory concentration: 24600 nM
Estimate against measurement, compound 4: 1.5-fold (0.17 log units) above; the measured number falls inside the stated range.
By their numbers in this assay, from the lowest: compounds 4, 1, 2 and 3 (each within the scatter of the next).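

In this assay, the exchange on the amine nitrogen in a ring that replaces (2-chlorophenyl)carbamoyl with the group holding sulfur and bromine (a 1.8-fold lower number from compound 3 to compound 4 (0.27 log units; within the scatter)) stays inside the scatter, even though this group differs from the one it replaces in two of its atoms. Among the compounds shown here, the first step at the amide-type nitrogen, 2-bromophenyl in place of naphthalen-1-yl (a 1.3-fold lower number from compound 2 to compound 4 (0.10 log units; within the scatter)), and the exchange of 2,6-dichlorobenzyl for the same sulfur and bromine group (a 1.2-fold lower number from compound 1 to compound 4 (0.07 log units; within the scatter)) also stay inside it, so all four groups on this ring nitrogen now fall in one band with no step that separates them. No available evidence bears on why these numbers lie so close together.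

Every group shown on this nitrogen carries a six-membered aromatic ring of carbon only, so it remains open whether a longer alkyl chain, a carboxylic acid or a basic amine there would leave that band. The rest of the shared core is the same in all four compounds, which leaves the effect of any change outside this position unknown.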